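Swapping Phenyl for Cyclopropyl on a Shared Amine

This account rests on a few compounds, and the source may have more. Where it says the series, first, only, none or still open, it means among the compounds named here.

In a functional assay on MGC-803 cells (Homo sapiens) for inhibition, read by sulforhodamine B assay (on this read-out higher numbers stand for weaker inhibition and lower numbers for stronger inhibition), compound 1 `O=C1C=C(NCc2ccccc2)C(=O)c2c1nc1n2[C@H]2OC[C@@H](O)[C@H]2OC1` gives 2670 nM, compound 2 `O=C1C(Nc2ccccc2)=CC(=O)c2c1nc1n2[C@H]2OC[C@@H](O)[C@H]2OC1` gives 1830 nM, and compound 3 `CCc1ccc(NC2=CC(=O)c3nc4n(c3C2=O)[C@H]2OC[C@@H](O)[C@H]2OC4)cc1` gives 1290 nM; the value of compound 2 lies among the other two, within the usual scatter of each. Compound 4 `O=C1C(NC2CC2)=CC(=O)c2c1nc1n2[C@H]2OC[C@@H](O)[C@H]2OC1` differs from compound 2 by cyclopropyl in place of phenyl on an amine nitrogen. Going by the values given here, the only measured step, a 2.1-fold lower number from compound 1 to compound 3 (0.32 log units; beyond the scatter), swaps one group on the same amine nitrogen for another, but neither group is phenyl or cyclopropyl, so it does not bear directly on this change. Without a close precedent, compound 4 is expected to show a step of a 1.4-fold higher number from compound 2 to compound 4 (0.14 log units; within the scatter), a shift within the scatter. The estimate for compound 4 is 2500 nM, with a range from 1000 nM to 6000 nM.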

Compound 4, half-maximal inhibitory concentration: > 4000 nM
Compound 4: only a limit was reported; the forecaster's own chance of this, stated with the estimate: 5%; at least 1.6-fold (0.20 log units) between middle value and limit.
By their numbers in this assay, from the lowest: compounds 3, 2 and 1 (each within the scatter of the next, the first and the last beyond it). At a limit, above all of these: compound 4.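

Going by these compounds alone, on this amine nitrogen, the earlier compounds all carry an aromatic ring, so they could not show what happens without one. Cyclopropyl in place of phenyl gives an at least 2.1-fold higher number from compound 2 to compound 4 (0.33 log units; beyond the scatter), which means weaker inhibition, beyond the usual scatter. Compound 4 has only a limit, not an exact number: the limit of > 4000 nM in this assay, at which 1 of the 4 values shown sits.

Going by these compounds, how much weaker compound 4 really is therefore stays open. It is also unclear whether a non-aromatic group of another kind on this nitrogen, such as a cyclohexyl ring or a longer chain, would fare any better.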